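The source may hold more compounds than are shown below. What is called first, only, known or untested is meant among the compounds shown, and "the series" means these compounds.

Measured so far in a functional assay on MDA-MB-231 cells (Homo sapiens) for cytotoxicity, read by MTT assay, with a stated time of 72 h; a higher number here means a weaker inhibitor, a lower number a stronger inhibitor:
- compound 1 `CCN(CC)Cc1ccc2nc(NC(=O)N/N=C/c3cn(Cc4ccc(C(C)(C)C)cc4)c4ccccc34)sc2c1`: 2120 nM
- compound 2 `CCN(CC)Cc1ccc2nc(NC(=O)N/N=C/c3cn(Cc4ccc(C)cc4)c4ccccc34)sc2c1`: 2010 nM
- compound 3 `CCN(CC)Cc1ccc2nc(NC(=O)N/N=C/c3cn(Cc4ccccc4)c4ccccc34)sc2c1`: 1470 nM

With its value of 1470 nM, compound 3 lies within the usual scatter of both other compounds, so these three cannot be ranked. The next compound is compound 4 `CCN(CC)Cc1ccc2nc(NC(=O)N/N=C/c3cn(Cc4ccc(Cl)c(Cl)c4)c4ccccc34)sc2c1`, in which 3,4-dichlorophenyl stands in place of phenyl on a saturated chain carbon bound to an aromatic nitrogen: 3,4-dichlorophenyl in place of phenyl on a saturated chain carbon bound to an aromatic nitrogen. Put another way, benzyl becomes 3,4-dichlorobenzyl.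

The closest evidence comes from the other changes to this benzyl group. These are a 1.4-fold lower number from compound 2 to compound 3 (0.14 log units; within the scatter), a 1.4-fold lower number from compound 1 to compound 3 (0.16 log units; within the scatter) and a 1.1-fold lower number from compound 1 to compound 2 (0.02 log units; within the scatter). All three stay within the scatter, even for a group as large as tert-butyl. Within the data shown here, no compound with chlorine has been measured, however, so the range must stay wide. No clear direction can be expected, and the expected step is a 1.1-fold higher number from compound 3 to compound 4 (0.04 log units; within the scatter), which is no larger than the scatter. The estimated value for compound 4 is 1600 nM, with an expected range from 700 nM to 3500 nM.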

Compound 4, half-maximal inhibitory concentration: 4490 nM
Compound 4: middle estimate off by 2.8-fold (0.45 log units), on the low side; measured number above the stated range.
By their numbers in this assay, from the lowest: compounds 3, 2 and 1 (each within the scatter of the next); then compound 4.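

Among these compounds, replacing benzyl with 3,4-dichlorobenzyl is the first change to this group that clearly shifts the result in this assay, with a 3.1-fold higher number from compound 3 to compound 4 (0.48 log units; beyond the scatter) showing that the position does not tolerate every change equally. The comparisons with the other two substituted benzyl groups agree: a 2.2-fold higher number from compound 2 to compound 4 (0.35 log units; beyond the scatter) and a 2.1-fold higher number from compound 1 to compound 4 (0.33 log units; beyond the scatter) also show a difference that the methyl and tert-butyl changes did not produce among themselves. A higher number means a weaker inhibitor, so compound 4 is the weakest of the four, but no accompanying measurement explains why adding the two chlorines has this effect.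

On these data alone, it remains open whether 4-chlorobenzyl, with a single chlorine, would give a similar result. It is also unclear how a methoxy group, an amine or a carboxylic acid on this benzyl ring would behave.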